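The source may report more compounds than this note shows. Statements on the series, on what has been measured and on what is new or still open speak of the compounds shown alone.

Measured compounds in an assay on isolated protein for agonist activity at melatonin receptor type 1C (Xenopus laevis), read by spectrophotometry; a lower number here means a smaller maximal response, a higher number a larger maximal response:
- compound 1 `COc1ccc(F)c(CNC(C)=O)c1` gives 100%
- compound 2 `CCC(=O)NCc1cc(OC)ccc1F` gives 69%
- compound 3 `COc1ccc(CNC(C)=O)cc1F` gives 77%

Compound 3 stands second of the three measured values in this assay. Its nearest neighbour is compound 2, whose value lies within the scatter of that of compound 3, so the two cannot be ordered; compound 1 lies beyond the scatter above compound 3.

Compound 4 `CCC(=O)NCc1ccc(OC)c(F)c1` is not yet measured. It differs from compound 3 by methyl in place of hydrogen on a saturated chain carbon bound to a carbonyl carbon, which cut one bond further out reads acetamido to propanoylamino.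

Going by the values given here, the one measured step that bears on this change is a number 31 percentage points lower from compound 1 to compound 2 (beyond the scatter), the same exchange of hydrogen for methyl on a saturated chain carbon bound to a carbonyl carbon, made on the core of compound 1. That step was large and downward. Among the compounds with values here, only one such step is known, so its size may not carry over exactly, but a drop beyond the scatter in this assay is expected for compound 4, estimated as a number 25 percentage points lower from compound 3 to compound 4 (beyond the scatter).

The value of compound 4 is therefore estimated at 52%, with a range from 35% to 70%.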

Compound 4, largest response reached (reported as efficacy), in percent of the reference or control that the assay uses: 51%
Compound 4: the middle estimate sits 1 percentage points above what was measured, and the stated range covers the measured number.
By their numbers in this assay, from the lowest: compound 4; then compounds 2 and 3 (each within the scatter of the next); then compound 1.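

In this assay, methyl in place of hydrogen on a saturated chain carbon bound to a carbonyl carbon gives a number 26 percentage points lower from compound 3 to compound 4 (beyond the scatter) and so repeats on a second core the downward step first seen on the core of compound 1. Acetamido to propanoylamino therefore no longer rests on a single reading: it lowers the maximal response on both cores shown. The size of the step also holds from one core to the other, as far as two cores can show: the same change on two cores in this assay, a number 31 percentage points lower (beyond the scatter) from compound 1 to compound 2 and a number 26 percentage points lower (beyond the scatter) from compound 3 to compound 4, 5 percentage points apart, within the scatter of two such steps

Going by these compounds, how a longer chain, a cyclopropyl group or an amine would read at this same carbon remains open, including whether the response keeps falling as the chain grows. Also open, on these data alone, is whether the step keeps its size on any core beyond these two.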